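Swapping Dimethoxyphenyl for Fluorophenyl in a Receptor Ligand

The compounds below may be only part of what the source reports. "The series", "measured", "known", "first", "only" and "open" are said of these compounds alone.

Compound 1 `COc1cccc(C(=O)NC2CCN(Cc3ccc4ccccc4c3)CC2)c1`: 29 nM
Compound 2 `COc1cc(OC)cc(C(=O)NC2CCN(Cc3ccc4ccccc4c3)CC2)c1`: 27 nM
Compound 3 `COc1cc(C(=O)NC2CCN(Cc3ccc4ccccc4c3)CC2)cc(OC)c1OC`: 286 nM

In an assay on isolated protein for binding affinity to melanin-concentrating hormone receptor 1 (Homo sapiens) (a lower number here means a stronger inhibitor, a higher number a weaker inhibitor), compound 2 gives the lowest of the three numbers, but compound 1 sits within the scatter of it (a 1.1-fold lower number from compound 1 to compound 2 (0.03 log units; within the scatter)), so the two cannot be ordered; compound 3 lies far higher (an 11-fold higher number from compound 2 to compound 3 (1.03 log units; beyond the scatter)). Compound 4 `O=C(NC1CCN(Cc2ccc3ccccc3c2)CC1)c1ccc(F)cc1` differs from compound 2 by 4-fluorophenyl in place of 3,5-dimethoxyphenyl on a carbonyl carbon. Neither measured step matches this change: each adds a single methoxy to the same ring, one without effect, one with a large loss. Removing both methoxy groups and placing fluorine on the ring is a change of another kind, so the direction is uncertain, and a moderate rise is expected. Compound 4 is estimated at 100 nM, with a range of 25 nM to 400 nM. This estimate for compound 4 means an expected step of a 3.7-fold higher number from compound 2 to compound 4 (0.57 log units; beyond the scatter).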

Compound 4, inhibition constant: 36 nM
Beside the measured number, compound 4's estimate is 2.8-fold (0.44 log units) above it; low and high end bracket the measured number.
By their numbers in this assay, from the lowest: compounds 2, 1 and 4 (each within the scatter of the next); then compound 3.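

On the carbonyl carbon, 4-fluorophenyl matches the methoxy-bearing rings (a 1.3-fold higher number from compound 2 to compound 4 (0.12 log units; within the scatter); a 1.2-fold higher number from compound 1 to compound 4 (0.09 log units; within the scatter)). In this assay, within the data shown here, compound 4 therefore shows that a methoxy group on this ring is not required for a number in this range, something the earlier compounds, all of which carry methoxy, could not show. Nothing available explains this match.

As far as these compounds go, whether the fluorine contributes at all remains open, as does the result of placing an amine or a carboxylic acid at that ring position.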